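The source may report more compounds than this note shows. Statements on the series, on what has been measured and on what is new or still open speak of the compounds shown alone.

Measured in a functional assay on HT-29 cells (Homo sapiens) for antiproliferative activity, read by MTT assay, with a stated time of 72 h; on this read-out lower numbers stand for stronger inhibition of growth and higher numbers for weaker inhibition of growth:
- Compound 1 `CC(=O)Nc1cc(OCc2ccccc2)nc(SCc2ccccc2)n1`: 65800 nM
- Compound 2 `Cc1ccc2nc(-c3ccc([N+](=O)[O-])cc3)cn2c1`: > 100000 nM (a limit, not a number)

Compound 2 stands at the limit of > 100000 nM in this assay, at which 1 of the 2 values shown sits. Its true value is therefore unknown.

Compound 3 `Cc1ccc2nc(-c3ccc(NCc4ccccc4)cc3)cn2c1` keeps the core of compound 2 and changes one group: benzylamino in place of nitro on an aromatic carbon, para to a large group (benzylamino in place of nitro on an aromatic carbon).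

Within the data shown here, no measured pair shows what such a swap does, so any expectation here is rough. Compound 1, on a different core, gives 65800 nM, which offers only a loose scale for a measurable result. A modest move towards stronger inhibition of growth is expected, and the estimated step is an at least 3.3-fold lower number from compound 2 to compound 3 (0.52 log units; beyond the scatter). Compound 3 is expected at 30000 nM, with an estimated range from 6000 nM to 100000 nM.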

Compound 3, concentration for 50% growth inhibition: 8800 nM
Estimate against measurement, compound 3: 3.4-fold (0.53 log units) above, within the range that was stated.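

The earlier compounds shown here held no pair that tested this position. In this assay, putting benzylamino in place of nitro on an aromatic carbon, para to a large group, gives an at least 11-fold lower number from compound 2 to compound 3 (1.05 log units; beyond the scatter), so growth inhibition on the shared core clearly responds to what sits at this position. The true size of this step remains unknown, since compound 2 has only a limit and not a number: the limit of > 100000 nM in this assay, at which 1 of the 3 values shown sits.

This single swap changes several things at once: nitro leaves, while an amine nitrogen with its hydrogen and a six-membered aromatic ring enter, and the compounds shown cannot say which of these parts matters. A plain amine or a methylamino group at the same position would separate the role of the nitrogen from that of the benzyl ring.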